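The compounds below may be only part of what the source reports. "The series", "measured", "known", "first", "only" and "open" are said of these compounds alone.

So far only two compounds have results, and they sit close together. In an ADME assay on Vero cells (Chlorocebus sabaeus) for cytotoxicity, read by resazurin assay, with a stated time of 72 h (a higher number here means a weaker inhibitor, a lower number a stronger inhibitor), compound 1 `O=C(CCN1CCN(c2ccc([N+](=O)[O-])cc2)CC1)c1ccc(F)c(Cl)c1` gives 116000 nM and compound 2 `O=C(CCN1CCN(c2ccc(Cl)cc2)CC1)c1ccc(Cl)c(F)c1` gives 175000 nM with the gap inside the usual scatter of repeated measurements, so compound 2 cannot be ranked apart from compound 1. Compound 3 `O=C(CCN1CCN(c2ccc([N+](=O)[O-])cc2)CC1)c1ccc(Cl)c(F)c1` comes from compound 2 by one change nitro in place of chloro on an aromatic carbon in which nitro takes the place of chloro on an aromatic carbon, para to a large group. Within the data shown here, no measured pair shows this change on its own. Compound 1 also carries a 4-nitrophenyl group and gives 116000 nM in line with compound 2, so no step beyond the scatter is expected in this assay for this change. The expected change is a 1.3-fold lower number from compound 2 to compound 3 (0.13 log units; within the scatter) at the middle of the estimate. For compound 3 the estimated value is 130000 nM with a likely range from 70000 nM to 240000 nM when it is measured.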

Compound 3, half-maximal inhibitory concentration: 89200 nM
The estimate for compound 3 lay 1.5-fold (0.16 log units) above the measured number, within the range that was stated.
By their numbers in this assay, from the lowest: compounds 3, 1 and 2 (each within the scatter of the next).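

In this assay, among these compounds, this is the first direct reading of nitro in place of chloro at this position, para to a large group: the change alone gives a 2.0-fold lower number from compound 2 to compound 3 (0.29 log units; within the scatter) and so does not move the number beyond the scatter. Swapping 3-chloro-4-fluorophenyl for 4-chloro-3-fluorophenyl on the carbonyl carbon, with the 4-nitrophenyl group kept, gives a 1.3-fold lower number from compound 1 to compound 3 (0.11 log units; within the scatter) and likewise leaves the two compounds unranked. No other measurement bears on these results.

On these data alone, whether an amine or a carboxylic acid at this position would give a step beyond the scatter remains open. As far as these compounds go, the nitro-for-chloro change has also been read on only one background, the one carrying 4-chloro-3-fluorophenyl, so its size with 3-chloro-4-fluorophenyl is unknown.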